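This account rests on a few compounds, and the source may have more. Where it says the series, first, only, none or still open, it means among the compounds named here.

Of the compounds shown here, three built on one shared core have been measured in an assay on CHO cells for displacement of a labelled ligand from prostaglandin D2 receptor 2 (Homo sapiens), read by scintillation counting; on this read-out lower numbers stand for stronger inhibition and higher numbers for weaker inhibition. Compound 1 `COc1ccccc1C#Cc1cc(Cl)ccc1OCC(=O)O` gives 190 nM. Compound 2 `Cc1ccc(S(=O)(=O)N2CCN(C)CC2)cc1C#Cc1cc(Cl)ccc1OCC(=O)O`, which carries 4-methylpiperazin-1-yl on a sulfonyl sulfur, gives 21 nM. Compound 3 `CCS(=O)(=O)c1ccc(C)c(C#Cc2cc(Cl)ccc2OCC(=O)O)c1`, with ethyl on that sulfonyl sulfur instead, gives 8.6 nM, the lowest number of the three; its nearest neighbour is compound 2 and its furthest is compound 1.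

Among the compounds with values here, only one measured step changes a single place: a 2.4-fold lower number from compound 2 to compound 3 (0.39 log units; beyond the scatter). Compound 4 `Cc1ccc(S(=O)(=O)N2CCOCC2)cc1C#Cc1cc(Cl)ccc1OCC(=O)O` has not yet been measured; it differs from compound 3 by morpholin-4-yl in place of ethyl on a sulfonyl sulfur. Within the data shown here, the one step that bears on this change is the swap from compound 2 to compound 3, in which a six-membered ring on the sulfonyl sulfur was replaced by ethyl and the number fell modestly. Morpholin-4-yl returns a six-membered ring to the sulfonyl sulfur, so the step is expected to run the other way, toward a higher number, and to stay modest in size. Compound 4 is therefore expected to give 15 nM, within a range of 6 nM to 40 nM. That estimate corresponds to an expected step of a 1.7-fold higher number from compound 3 to compound 4 (0.24 log units; within the scatter).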

Compound 4, inhibition constant: 3.6 nM
Estimate against measurement, compound 4: 4.2-fold (0.62 log units) above, outside the stated range (below it).
By their numbers in this assay, from the lowest: compound 4; then compound 3; then compound 2; then compound 1.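

Compound 4 shows that putting a six-membered ring on the sulfonyl sulfur does not by itself weaken binding in this assay. Going from ethyl to morpholin-4-yl gives a 2.4-fold lower number from compound 3 to compound 4 (0.38 log units; beyond the scatter), the opposite direction to the ethyl-for-4-methylpiperazin-1-yl swap, which had made a ring look unfavourable. The identity of the ring matters, as exchanging one ring for the other gives a 5.8-fold lower number from compound 2 to compound 4 (0.77 log units; beyond the scatter), so at this place ethyl lies in order between the two rings and neither size nor the presence of a ring alone accounts for the three numbers; no supporting data are available to explain this order.

From the compounds shown here alone, how piperidin-1-yl, a six-membered ring without the oxygen, or an open-chain amine such as dimethylamino would behave on this sulfonyl sulfur remains open, as does a longer chain such as propyl in place of ethyl. Going by these compounds, all three sulfonyl compounds also share the rest of their structure, so it is unknown whether the same order would hold on a different core or in a different kind of test.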